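Pyridyl swap on an amide nitrogen, beside a thienyl change

The source may report more compounds than this note shows. Statements on the series, on what has been measured and on what is new or still open speak of the compounds shown alone.

Measured so far:
- compound 1 `CC(C)n1ncc2c(C(=O)Nc3ccccn3)cc(-c3ccsc3)nc21` gives 25000 nM
- compound 2 `CC(C)n1ncc2c(C(=O)Nc3cccnc3)cc(-c3ccsc3)nc21` gives 37000 nM
- compound 3 `CC(C)n1ncc2c(C(=O)Nc3cccnc3)cc(-c3cccs3)nc21` gives > 200000 nM, which is a limit of the assay

All three were tested in an ADME assay on LLC-MK2 cells (Macaca mulatta) for cytotoxicity, read by spectrophotometry and crystal violet staining, with a stated time of 4 days; a lower number here means that less compound is tolerated, a higher number that more compound is tolerated. Compound 2 and compound 1 share their core and differ only in the ring carried by the amide nitrogen: pyridin-2-yl in place of pyridin-3-yl on an amide-type nitrogen. The step this made is a 1.5-fold lower number from compound 2 to compound 1 (0.17 log units; within the scatter), so the two values cannot be told apart. Compound 2 and compound 3 differ in their cores, in the thienyl group attached to the bicyclic part: thiophen-2-yl in place of thiophen-3-yl on an aromatic carbon. Here the step is an at least 5.4-fold higher number from compound 2 to compound 3 (0.73 log units; beyond the scatter). The value of compound 3 is a limit of the assay (the limit of > 200000 nM in this assay, at which 1 of the 3 values shown sits), and no number is known for it.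

Compound 4 `CC(C)n1ncc2c(C(=O)Nc3ccccn3)cc(-c3cccs3)nc21` has not yet been measured in this assay. It is related to compound 3 in the same way that compound 1 is related to compound 2: pyridin-2-yl in place of pyridin-3-yl on an amide-type nitrogen, at the same place, so this is the same change made on the other core. From compound 3 to compound 4 the expected step is a number no higher from compound 3 to compound 4 (the limit leaves the size open), resting on the fact that the same change gave a 1.5-fold lower number from compound 2 to compound 1 (0.17 log units; within the scatter), a step that stayed within the scatter. Since compound 3 already sits at a limit, compound 4 is expected to land near that limit as well, and it is likely that this assay again reports only a limit for compound 4. The estimate for compound 4 is 200000 nM, between 90000 nM and 400000 nM.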

Compound 4, half-maximal cytotoxic concentration: > 200000 nM
Compound 4 ended at the assay's limit; the forecaster's own chance of this, stated with the estimate: 65%; the middle value sits exactly at the limit.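

In this assay, with pyridin-2-yl on the amide nitrogen, putting thiophen-2-yl in place of thiophen-3-yl gives an at least 8.0-fold higher number from compound 1 to compound 4 (0.90 log units; beyond the scatter). The same change thus raises the number in both pairs shown, one carrying pyridin-3-yl and the other pyridin-2-yl, so its direction carries over from one to the other, although two pairs cannot establish a rule for the whole series: the same change on two cores in this assay, an at least 5.4-fold higher number (0.73 log units; beyond the scatter) from compound 2 to compound 3 and an at least 8.0-fold higher number (0.90 log units; beyond the scatter) from compound 1 to compound 4; the limit leaves it open whether they differ. The sizes of the two steps cannot be compared, and the step from compound 3 to compound 4 cannot be read, since both compounds sit at a limit of the assay rather than at a measured number: the limit of > 200000 nM in this assay, at which 2 of the 4 values shown sit.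

As far as these compounds go, how far compound 3 and compound 4 lie past that limit remains unknown, so these compounds cannot show whether swapping pyridin-3-yl for pyridin-2-yl makes any difference when thiophen-2-yl is present. From the compounds shown here alone, it also remains open whether thiophen-2-yl would have the same effect with a phenyl ring or a longer alkyl chain on the amide nitrogen, and how a furan-2-yl ring would behave in place of the thienyl group.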